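Shifting the piperidine attachment on the amine side chain

A few compounds are considered here, and "the series" means these few. Any claim that something is new, unique, unknown or untested is made for them only; others in the source may bear on it.

Three compounds share one core and were studied in an ADME assay on microsomes from liver (Mus musculus) for metabolic stability, read by LC-MS, with a stated time of 10 min, tested at 0.5 uM; on this read-out higher numbers stand for a more stable compound and lower numbers for a less stable compound. Compound 1 `c1ccc2c(c1)CN[C@@H](CN(CC1CCNCC1)[C@H]1CCCc3cccnc31)C2` gives 13% in this assay, the lowest of the three numbers. Compound 2 `c1ccc2c(c1)CN[C@@H](CN(CCCN1CCNCC1)[C@H]1CCCc3cccnc31)C2` gives 92%, and compound 3 `c1cnc2c(c1)CN[C@H](CN(CCCN1CCNCC1)[C@H]1CCCc3cccnc31)C2` gives 63%. The step of a number 79 percentage points higher from compound 1 to compound 2 (beyond the scatter) is the large one, and a number 29 percentage points lower from compound 2 to compound 3 (beyond the scatter) is the modest one.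

The unmeasured compound 4 `c1ccc2c(c1)CN[C@@H](CN(CC[C@H]1CCCNC1)[C@H]1CCCc3cccnc31)C2` differs from compound 1 in one place: (piperidin-3-yl)methyl in place of piperidin-4-yl on a saturated chain carbon bound to an amine nitrogen.

Within the data shown here, only the step from compound 1 to compound 2 touches the same position, and it shows that exchanging the group on that saturated chain carbon can move this assay a long way, because a number 79 percentage points higher from compound 1 to compound 2 (beyond the scatter). The change from compound 1 to compound 4 is much smaller in kind, keeping a piperidine ring and adding a single carbon between it and the chain, so the expectation is a rise that is clearly smaller than the step to compound 2, yet likely beyond the scatter, estimated as a number 17 percentage points higher from compound 1 to compound 4 (beyond the scatter). The step from compound 2 to compound 3 concerns a different part of the molecule and gives no direct guidance here. Compound 4 is thus expected to reach about 30%, with a range from 8% to 65%.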

Compound 4, percent of the compound remaining: 56%
For compound 4 the middle estimate is 26 percentage points below the measured one; measured number inside the range.
By their numbers in this assay, from the lowest: compound 1; then compounds 4 and 3 (each within the scatter of the next); then compound 2.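

In this assay, the place on a saturated chain carbon bound to an amine nitrogen proves sensitive even to a change that keeps a piperidine ring: with (piperidin-3-yl)methyl in place of piperidin-4-yl, the result is a number 43 percentage points higher from compound 1 to compound 4 (beyond the scatter). A large gain at this place therefore does not require the piperazin-1-yl group of compound 2, although that group still gives the highest number of this pair, with a number 36 percentage points lower from compound 2 to compound 4 (beyond the scatter) for piperidin-3-yl in place of (piperazin-1-yl)methyl on a saturated chain carbon, two bonds along the chain from an amine nitrogen. No evidence is at hand to account for either step.

The compounds shown leave open how much of the rise belongs to the changed ring attachment and how much to the added carbon, a question that (piperidin-4-yl)methyl at this place would separate. Also open, going by these compounds, are how the opposite configuration at the defined stereocentre of (piperidin-3-yl)methyl would read and where a morpholin-4-yl group on the same chain would fall.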